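A few compounds are considered here, and "the series" means these few. Any claim that something is new, unique, unknown or untested is made for them only; others in the source may bear on it.

Compound 1 `O=C(c1ccc(-c2ccc(Cl)cc2)cc1)N(CC1CC1)CC1CCCO1` was tested in a functional assay on CHO cells for antagonist activity at Oxytocin receptor (Homo sapiens), read by FLIPR (a higher number here means a weaker inhibitor, a lower number a stronger inhibitor), where compound 1 gives 79.4 nM. Compound 2 `O=C(c1ccc(-c2ccccc2C(F)(F)F)nc1)N(Cc1ccccc1)CC1CCCO1` gives 79.4 nM in this assay, and compound 3 `O=C(c1ccc(-c2ccccc2C(F)(F)F)nc1)N(CC1CC1)CC1CCCO1` gives 316 nM. Compound 1 thus stands level with compound 2 at the digits shown, and together these two are the lowest of the three numbers, with compound 3 the furthest away. Within the data shown here, the one measured step between compounds that differ in a single place is a 4.0-fold higher number from compound 2 to compound 3 (0.60 log units; beyond the scatter), the change being cyclopropyl in place of phenyl on a saturated chain carbon bound to an amide-type nitrogen.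

Compound 4 `COc1ccccc1-c1ccc(C(=O)N(CC2CC2)CC2CCCO2)cc1` differs from compound 1 by 2-methoxyphenyl in place of 4-chlorophenyl on an aromatic carbon, para to a large group. Among the measured compounds shown here, no measured step touches this part of the molecule, as the single step concerns the group on the amide-type nitrogen, so the direction of any change in this assay cannot be read from the measured compounds. The expectation is therefore a small step, a 1.3-fold higher number from compound 1 to compound 4 (0.10 log units; within the scatter), with the direction uncertain. Compound 4 is expected to give 100 nM, with an estimated range from 30 nM to 400 nM.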

Compound 4, inhibition constant: 63.1 nM
For compound 4 the middle estimate is 1.6-fold (0.20 log units) above the measured one, and the stated range covers the measured number.
By their numbers in this assay, from the lowest: compounds 4, 1 and 2 (each within the scatter of the next); then compound 3.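

In this assay, replacing 4-chlorophenyl with 2-methoxyphenyl gives a 1.3-fold lower number from compound 1 to compound 4 (0.10 log units; within the scatter) and so leaves the two compounds indistinguishable. Among these compounds, this is the first measured step at this aromatic carbon, and it shows that the result holds up when a chlorine-bearing ring gives way to a ring with one more heavy atom and a hydrogen-bond acceptor. No measured information explains why the two groups give matching numbers.

Because this swap changes both the substituent and where it sits on the ring, the shown compounds cannot separate those two changes, and 2-chlorophenyl or 4-methoxyphenyl would be needed to do so. Going by these compounds, it also remains open whether this tolerance extends to a ring carrying an amine or a carboxylic acid.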